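Methyl to chloro swap in a porcupine inhibitor series

A few compounds are considered here, and "the series" means these few. Any claim that something is new, unique, unknown or untested is made for them only; others in the source may bear on it.

Measured so far, in an assay on L cells for inhibition of Protein-serine O-palmitoleoyltransferase porcupine (Mus musculus), read by reporter gene assay, with a stated time of 24 h; on this read-out lower numbers stand for an effect already at smaller amounts and higher numbers for an effect only at larger amounts of compound:
compound 1 `COc1ccccc1-n1c(SCC(=O)Nc2nc3ccc(Cl)cc3s2)nc2c(c1=O)SCC2`, 50 nM
compound 2 `COc1ccccc1-n1c(SCC(=O)Nc2nc3ccc(C)cc3s2)nc2c(c1=O)SCC2`, 25 nM
compound 3 `Cc1ccc2nc(NC(=O)CNC(=O)c3nn(-c4ccc(F)cc4)c(=O)c4ccccc34)sc2c1`, 100 nM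

Compound 1 and compound 2 share one core and differ by chloro in place of methyl on an aromatic carbon; the step is a 2.0-fold higher number from compound 2 to compound 1 (0.30 log units; within the scatter), so the two values are not told apart here. Compound 3 carries a different core; how the two cores differ is not broken down here. Compound 3 has the highest number of the three, within the scatter of compound 1 but beyond it relative to compound 2.

Compound 4 `O=C(CNC(=O)c1nn(-c2ccc(F)cc2)c(=O)c2ccccc12)Nc1nc2ccc(Cl)cc2s1` is not yet measured. It differs from compound 3 by chloro in place of methyl on an aromatic carbon, the same change as that from compound 2 to compound 1. Because the earlier step was a 2.0-fold higher number from compound 2 to compound 1 (0.30 log units; within the scatter), a similar step is expected for compound 4, a 2.0-fold higher number from compound 3 to compound 4 (0.30 log units; within the scatter). Compound 4 is therefore estimated at 200 nM in this assay, expected between 70 nM and 600 nM.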

Compound 4, half-maximal effective concentration: 25 nM
Compound 4: middle estimate off by 8.0-fold (0.90 log units), on the high side; the measured number lies below the stated range.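

On the core of compound 3, in this assay, the change from 6-methyl-1,3-benzothiazol-2-yl to 6-chloro-1,3-benzothiazol-2-yl gives a 4.0-fold lower number from compound 3 to compound 4 (0.60 log units; beyond the scatter) and so lowers the number. The same change does not carry over as one fixed step between the two cores: the same change on two cores in this assay, a 2.0-fold higher number (0.30 log units; within the scatter) from compound 2 to compound 1 and a 4.0-fold lower number (0.60 log units; beyond the scatter) from compound 3 to compound 4, 8.0-fold (0.90 log units) apart, beyond the scatter of two such steps

This rests on a single pair of compounds on each core, so it shows that a step read on one core is a poor guide to the other, but it does not show why the two steps part.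

Still open, as far as these compounds go, is whether other groups in this place on the benzothiazole, such as methoxy, nitrile or an amine, would also behave differently on the two cores. A third core carrying the same methyl and chloro pair would show whether the core of compound 1 or the core of compound 3 is the more typical case.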